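Swapping the aryl group on a coumarin-pyrazole diester

This account rests on a few compounds, and the source may have more. Where it says the series, first, only, none or still open, it means among the compounds named here.

The measured compounds:
compound 1, `CCOC(=O)c1c(-c2c(Cl)c3ccccc3oc2=O)nn(-c2cccc(C)c2)c1C(=O)OCC`, 32000 nM
compound 2, `CCOC(=O)c1c(-c2c(Cl)c3cc(C)ccc3oc2=O)nn(-c2ccccc2)c1C(=O)OCC`, 50000 nM
compound 3, `CCOC(=O)c1c(-c2cc3ccccc3oc2=O)nn(-c2cccc(C)c2)c1C(=O)OCC`, 47000 nM

All three share a coumarin core joined to a pyrazole that carries two ethoxycarbonyl groups and an aryl group on a ring nitrogen. In a functional assay on DU-145 cells (Homo sapiens) for cytotoxicity, read by MTT assay, with a stated time of 48 h (a lower number here means a stronger inhibitor, a higher number a weaker inhibitor), compound 3 sits second highest of the three numbers, between compound 1 and compound 2, and the differences to both lie within the scatter of this assay; the three compounds are, as far as these numbers can tell, indistinguishable. Within the data shown here, the one single-point step that is measured, a 1.5-fold higher number from compound 1 to compound 3 (0.17 log units; within the scatter), also stays within the scatter. Among the measured compounds shown here, compound 1 and compound 2 differ in two places at once, so their pair says only that both numbers are high and close together.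

Compound 4, `CCOC(=O)c1c(-c2cc3ccccc3oc2=O)nn(-c2ccc(Cl)cc2)c1C(=O)OCC`, follows from compound 3 by the change (4-chlorophenyl in place of 3-methylphenyl on an aromatic nitrogen). For the measured compounds named here, no measured step touches the aryl group on the pyrazole nitrogen, so there is no direct precedent for this change. Going by the values given here, the only evidence is that every variation tried so far has left this assay essentially unmoved, and on that basis the expected step of a 1.0-fold lower number from compound 3 to compound 4 (0.02 log units; within the scatter) is none beyond the scatter. Compound 4 is therefore estimated at 45000 nM in this assay, with a range from 18000 nM to 110000 nM.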

Compound 4, half-maximal inhibitory concentration: 26000 nM
For compound 4 the middle estimate is 1.7-fold (0.24 log units) above the measured one; low and high end bracket the measured number.
By their numbers in this assay, from the lowest: compounds 4, 1, 3 and 2 (each within the scatter of the next).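

Among these compounds, this is the first measured change at the aryl group on the aromatic nitrogen, and swapping 3-methylphenyl for 4-chlorophenyl there gives in this assay a 1.8-fold lower number from compound 3 to compound 4 (0.26 log units; within the scatter), so this swap at this position cannot be told apart from no effect. The two groups match in what can be counted: each has the same number of heavy atoms and one six-membered aromatic ring of carbon only, with no hydrogen-bond donors or acceptors and no net charge. The swap alters both the substituent and where it sits on the ring, and nothing shown separates those two parts or offers an explanation for the number obtained.

The compounds shown leave open whether the same substituent moved around the ring, or a different one placed on it, such as an amine or a carboxylic acid, would shift the number beyond the scatter. They also leave open what a carboxylic acid or a longer chain would do in place of an ethoxycarbonyl group on the shared core, since neither ester has been varied in these compounds.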